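This account rests on a few compounds, and the source may have more. Where it says the series, first, only, none or still open, it means among the compounds named here.

Compound 1 `CN(C)c1ccc(C(=O)NCc2ccc(NS(C)(=O)=O)cc2Cl)cc1` gives 1460 nM in an assay on HeLa cells for agonist activity at Bile acid receptor (Homo sapiens), read by a luciferase reporter, with a stated time of 24 h; on this read-out lower numbers stand for an effect already at smaller amounts and higher numbers for an effect only at larger amounts of compound. Compound 2 `CS(=O)(=O)Nc1ccc(CNC(=O)c2ccc(N3CCC3)cc2)c(Cl)c1` gives 13000 nM. Compound 3 `CS(=O)(=O)Nc1ccc(CNC(=O)c2ccc(N3CCCCC3)cc2)c(Cl)c1` gives 410 nM.

Compound 3 therefore stands lowest of the three in this assay, its steps to the other two being beyond the scatter. Compound 4 `CS(=O)(=O)Nc1ccc(CNC(=O)c2ccc(C(F)(F)C(F)(F)F)cc2)c(Cl)c1` carries a change at the same position: 1,1,2,2,2-pentafluoroethyl in place of piperidin-1-yl on an aromatic carbon. The steps seen so far all swap one nitrogen-linked group for another, with a 3.6-fold lower number from compound 1 to compound 3 (0.55 log units; beyond the scatter) and a 32-fold lower number from compound 2 to compound 3 (1.50 log units; beyond the scatter) favouring the six-membered ring, while an 8.9-fold higher number from compound 1 to compound 2 (0.95 log units; beyond the scatter) runs the other way. None of them covers a carbon-linked, fluorinated group, so they bear only loosely on compound 4. For compound 4 the expected step is a 6.1-fold higher number from compound 3 to compound 4 (0.79 log units; beyond the scatter), toward a higher number. Compound 4 is estimated at 2500 nM, with a range of 500 nM to 15000 nM.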

Compound 4, half-maximal effective concentration: 3220 nM
For compound 4 the middle estimate is 1.3-fold (0.11 log units) below the measured one, within the range that was stated.
By their numbers in this assay, from the lowest: compound 3; then compound 1; then compound 4; then compound 2.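

In this assay the place para to a large group is not limited to nitrogen-linked groups, since 1,1,2,2,2-pentafluoroethyl, with no ring and no hydrogen-bond acceptor, still gives a measurable effect. Replacing piperidin-1-yl with it costs activity, with a 7.9-fold higher number from compound 3 to compound 4 (0.90 log units; beyond the scatter), but it outperforms azetidin-1-yl, with a 4.0-fold lower number from compound 2 to compound 4 (0.61 log units; beyond the scatter), and falls short of dimethylamino, with a 2.2-fold higher number from compound 1 to compound 4 (0.34 log units; beyond the scatter). No supporting data explain this order.

Still open, going by these compounds, is whether the fluorine atoms or the carbon link matter more. A plain ethyl chain or a trifluoromethyl group at this place would help separate the two.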